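The source may report more compounds than this note shows. Statements on the series, on what has been measured and on what is new or still open speak of the compounds shown alone.

Measured in an ADME assay on L6 cells (Rattus norvegicus) for cytotoxicity, read by resazurin assay, with a stated time of 72 h; on this read-out lower numbers stand for stronger inhibition and higher numbers for weaker inhibition:

compound 1 `CN1CCN(CCC(=O)N2CCC3(N(C)C)CC(c4ccccc4)C2C(c2ccccc2)C3)CC1`: 128000 nM
compound 2 `CCN(CC)CC(=O)OC1CC2(N(C)C)CC(c3ccccc3)C1C(c1ccccc1)C2`: 30100 nM
compound 3 `CN1CCN(CCC(=O)NC2CC3(N(C)C)CC(c4ccccc4)C2C(c2ccccc2)C3)CC1`: 95000 nM

Compound 1 has the highest number of the three, at 128000 nM, but compound 3, at 95000 nM, lies within the usual scatter of it, so these two cannot be told apart in this assay. Compound 2, at 30100 nM, has a lower number than compound 1, and that gap lies beyond the scatter.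

Compound 4 `CN1CCN(CC(=O)N2CCC3(N(C)C)CC(c4ccccc4)C2C(c2ccccc2)C3)CC1` has not been measured yet. It differs from compound 1 in one place: 4-methylpiperazin-1-yl in place of (4-methylpiperazin-1-yl)methyl on a saturated chain carbon bound to a carbonyl carbon. In words, 4-methylpiperazin-1-yl stands in place of (4-methylpiperazin-1-yl)methyl on a saturated chain carbon bound to a carbonyl carbon. Read one bond further out, 2-(4-methylpiperazin-1-yl)ethyl becomes (4-methylpiperazin-1-yl)methyl.

Within the data shown here, no two measured compounds differ in only one place, so no measured step guides this forecast directly. The expectation starts from compound 1 at 128000 nM, and the change leaves the piperazine ring in place. The expected result is a 1.2-fold lower number from compound 1 to compound 4 (0.09 log units; within the scatter), which would stay within the scatter. The estimate for compound 4 is 105000 nM, with an expected range from 45000 nM to 220000 nM.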

Compound 4, half-maximal inhibitory concentration: 195000 nM
The estimate for compound 4 lay 1.9-fold (0.27 log units) below the measured number; low and high end bracket the measured number.
By their numbers in this assay, from the lowest: compound 2; then compounds 3, 1 and 4 (each within the scatter of the next, the first and the last beyond it).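

In this assay, among these compounds, the swap of (4-methylpiperazin-1-yl)methyl for 4-methylpiperazin-1-yl on a saturated chain carbon bound to a carbonyl carbon gives the first comparison of compounds that differ in one place only: a 1.5-fold higher number from compound 1 to compound 4 (0.18 log units; within the scatter). Seen one bond further out, the group on the carbonyl can be either 2-(4-methylpiperazin-1-yl)ethyl or (4-methylpiperazin-1-yl)methyl without a difference that this read-out can resolve, so this change does not separate the two compounds. No measurement shown here bears on what lies behind this result.

This single pair leaves open whether a longer chain, such as 3-(4-methylpiperazin-1-yl)propyl, or a different group on the chain, such as a morpholine ring or a diethylamino group, would give a step beyond the scatter. It also leaves open whether the same swap would give a similar step on compound 3, since one pair on the core of compound 1 cannot show whether the result carries over to another compound.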